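Cyanosulfanyl in Place of Formyl on a Shared Core

The source may hold more compounds than are shown below. What is called first, only, known or untested is meant among the compounds shown, and "the series" means these compounds.

Compound 1 `O=Cc1c(-c2ccc(Cl)cc2)nc2sc(Cc3ccc(Cl)cc3)nn12` stands at the low end of three numbers in a functional assay on HeLa cells (Homo sapiens) for cytotoxicity, with a stated time of 72 h (a lower number here means a stronger inhibitor, a higher number a weaker inhibitor), where compound 1 gives 16000 nM. Compound 2 `Cc1ccc(-c2nc3sc(Cc4ccc(Cl)cc4)nn3c2C=O)cc1` gives 21000 nM, and compound 3 `O=Cc1c(-c2ccccc2)nc2sc(Cc3ccc(Cl)cc3)nn12` gives 45000 nM. The step of a 1.3-fold higher number from compound 1 to compound 2 (0.12 log units; within the scatter) stays within the scatter, whereas a 2.8-fold higher number from compound 1 to compound 3 (0.45 log units; beyond the scatter) and a 2.1-fold higher number from compound 2 to compound 3 (0.33 log units; beyond the scatter) are modest steps beyond it. All three measured steps concern the group on the phenyl ring carried by the core; none of them touches the formyl group. Compound 4 `N#CSc1c(-c2ccc(Cl)cc2)nc2sc(Cc3ccc(Cl)cc3)nn12` differs from compound 1 in cyanosulfanyl in place of formyl on an aromatic carbon. Within the data shown here, no measured step bears on this exchange, so the expectation rests on compound 1 alone, with 16000 nM as the anchor and a wide margin around it. Compound 4 is therefore expected to give 16000 nM, within a range from 4000 nM to 64000 nM. The estimated step of no change at the digits printed from compound 1 to compound 4 (within the scatter) is expected to amount to no change beyond the scatter in either direction.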

Compound 4, half-maximal inhibitory concentration: 20000 nM
Beside the measured number, compound 4's estimate is 1.3-fold (0.10 log units) below it; measured number inside the range.
By their numbers in this assay, from the lowest: compounds 1, 4 and 2 (each within the scatter of the next); then compound 3.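

Among these compounds, the first measured change at this position, on an aromatic carbon of a five-membered aromatic ring with 2 nitrogen, gives a 1.3-fold higher number from compound 1 to compound 4 (0.10 log units; within the scatter) in this assay. Until now, every step had concerned the group on the phenyl ring, so the data said nothing about the formyl group; here, with the 4-chlorophenyl group kept, cyanosulfanyl stands in its place and the number stays within the scatter, so for this pair a carbonyl at this carbon is not needed to keep the reading. No measurement among the data shown accounts for this result.

On these data alone, how an amine, a carboxylic acid or a longer chain on this carbon would read in this assay remains open. Also open, as far as these compounds go, is whether the same exchange would leave the numbers of compound 2 and compound 3 within the scatter.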